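This account rests on a few compounds, and the source may have more. Where it says the series, first, only, none or still open, it means among the compounds named here.

Measured compounds:
- compound 1, `Cn1ncc(Cl)c1-c1cc(C(=O)N[C@@H]2CN[C@H](CCn3cncn3)C[C@H]2c2ccc(Cl)c(Cl)c2)oc1Cl`: 60 nM
- compound 2, `Cn1ncc(Cl)c1-c1cc(C(=O)N[C@@H]2CN[C@H](CC(=O)NC3CC3)C[C@H]2c2ccc(Cl)c(Cl)c2)oc1Cl`: 190 nM
- compound 3, `CC(=O)NCC[C@@H]1C[C@@H](c2ccc(F)c(F)c2)[C@H](NC(=O)c2cc(-c3c(Cl)cnn3C)c(Cl)o2)CN1`: 130 nM

In a functional assay on LNCaP cells (Homo sapiens) for antiproliferative activity (a higher number here means a weaker inhibitor, a lower number a stronger inhibitor), compound 3 stands second highest of the three numbers. Its nearest neighbour is compound 2, whose number is within the scatter of that of compound 3, so the two cannot be told apart. Compound 1 gives the lowest number, and its gap to compound 3 lies beyond the scatter.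

Compound 4, `Cn1ncc(Cl)c1-c1cc(C(=O)N[C@@H]2CN[C@H](CCO)C[C@H]2c2ccc(F)c(F)c2)oc1Cl`, is the compound not yet measured. It differs from compound 3 in one place: hydroxy in place of acetamido on a saturated chain carbon, two bonds along the chain from a saturated ring carbon

Only one measured step exists among these compounds, a 3.2-fold higher number from compound 1 to compound 2 (0.50 log units; beyond the scatter). That step swaps one group for another on the same side chain region, but neither group is the acetamido or the hydroxy involved here, and the shared core of compounds 1 and 2 also carries different halogens from compound 3. It shows that a change on this chain can move the number modestly, but gives no direction for the present change. The step of a 1.2-fold higher number from compound 3 to compound 4 (0.06 log units; within the scatter) is therefore expected to be small, likely within the scatter, with the direction uncertain. For compound 4 the estimated value in this assay is 150 nM, with a range from 60 nM to 400 nM.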

Compound 4, half-maximal inhibitory concentration: 60 nM
Compound 4: the middle estimate sits 2.5-fold (0.40 log units) above what was measured, within the range that was stated.
By their numbers in this assay, from the lowest: compounds 1 and 4 (each within the scatter of the next); then compounds 3 and 2 (each within the scatter of the next).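

In this assay, putting hydroxy in place of acetamido on a saturated chain carbon, two bonds along the chain from a saturated ring carbon, gives a 2.2-fold lower number from compound 3 to compound 4 (0.34 log units; beyond the scatter) and so shows that the whole acetamido group can go from this position without the number rising. For the compounds shown here, this is the first measured change at this position involving either of these two groups, and unlike the earlier step, a 3.2-fold higher number from compound 1 to compound 2 (0.50 log units; beyond the scatter), it gives a direction for this particular exchange: the smaller group, with one heavy atom instead of four, gives the lower number, although both groups count the same hydrogen-bond donors and acceptors. Nothing available explains why the number moves.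

Going by these compounds, it remains open whether hydroxy is the best end for this chain, as an amine or a carboxylic acid at the same place, or a longer chain ending in hydroxy, could give a lower or a higher number. Going by these compounds alone, it also remains open whether the same exchange would give a step of similar size in a compound that otherwise matches compound 1, as this change is seen in only one pair.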